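From benzyloxy to allyloxy: compound 2 to compound 4

A few compounds are considered here, and "the series" means these few. Any claim that something is new, unique, unknown or untested is made for them only; others in the source may bear on it.

In a functional assay on HCT-116 cells (Homo sapiens) for inhibition, read by sulforhodamine B assay, with a stated time of 48 h (a lower number here means a stronger inhibitor, a higher number a weaker inhibitor), compound 1 `CCOC(=O)CO/N=C(/c1ccc(OC)c(OC)c1OC)c1cccc2ccccc12` gives 3360 nM, and compound 3 `COc1ccc(/C(=N/OCC(=O)O)c2cccc3ccccc23)c(OC)c1OC` gives 4980 nM. The step between them, a 1.5-fold higher number from compound 1 to compound 3 (0.17 log units; within the scatter), puts hydrogen in place of ethyl and lies within the scatter.

Compound 2 `COc1ccc(C(OCc2ccccc2)c2cccc3ccccc23)c(OC)c1OC` gives only a limit, > 20000 nM, and no number. The series therefore holds (the limit of > 20000 nM in this assay, at which 1 of the 3 values shown sits).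

Compound 4 `C=CCOC(c1ccc(OC)c(OC)c1OC)c1cccc2ccccc12` is the next to be read against compound 2. The difference is vinyl in place of phenyl on a saturated chain carbon bound to an oxygen on a saturated carbon. The same change also reads as benzyloxy to allyloxy.

Among the compounds with values here, no measured step covers this change. The only one available, a 1.5-fold higher number from compound 1 to compound 3 (0.17 log units; within the scatter), concerns a different group and gives no size to carry over. The expectation therefore rests on compound 2 alone, which marks its limit at > 20000 nM, and on the shared core that compound 4 retains.

A modest move toward a lower number is expected, as the estimated step of an at least 1.4-fold lower number from compound 2 to compound 4 (0.15 log units; that floor lies within the scatter), and a second limit reading remains quite possible.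

For compound 4 the estimate in this assay is 14000 nM, with an expected range from 6000 nM to 30000 nM.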

Compound 4, half-maximal inhibitory concentration: > 20000 nM
Compound 4 was reported as a limit; the forecaster's own chance of this, stated with the estimate: 40%; middle value at least 1.4-fold (0.15 log units) away from the limit.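

Compound 2 and compound 4 are both reported only as limits in this assay, so the step from benzyloxy to allyloxy cannot be read: the limit of > 20000 nM in this assay, at which 2 of the 4 values shown sit.

The compounds shown leave open how far vinyl in place of phenyl shifts the number in this assay, and whether any group at this place gives a readable value.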